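The source may report more compounds than this note shows. Statements on the series, on what has been measured and on what is new or still open speak of the compounds shown alone.

Of the compounds shown here, two have been measured so far in a functional assay on HCT-116 cells (Homo sapiens) for cytotoxicity, read by MTT assay, with a stated time of 48 h; a higher number here means a weaker inhibitor, a lower number a stronger inhibitor. Compound 1 `CCCCCCCCOc1ccc2c(Cl)ccnc2c1` gives 2820 nM in this assay. Compound 2 `CN(C)CCNc1ccnc2cc(OCc3ccccc3)ccc12` gives 1980 nM in this assay. The two numbers lie within the scatter of repeated measurements, so neither compound can be set apart from the other on this evidence.

Compound 3 `CCOc1ccc2c(Cl)ccnc2c1` has not yet been measured. It differs from compound 1 in one place: hydrogen in place of hexyl on a saturated chain carbon, two bonds along the chain from an oxygen on an aromatic ring. The alkoxy chain on the shared core is thereby shortened from octyl to ethyl.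

Among the compounds with values here, no measured pair of compounds shows what such a shortening does here, so the expectation rests on the single value of compound 1. Compound 3 is expected to be a weaker inhibitor than compound 1, with an estimated step of a 2.8-fold higher number from compound 1 to compound 3 (0.45 log units; beyond the scatter) that reaches beyond the scatter. For compound 3 the estimated value in this assay is 8000 nM, within a range from 3000 nM to 25000 nM.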

Compound 3, half-maximal inhibitory concentration: 3160 nM
Compound 3: middle estimate off by 2.5-fold (0.40 log units), on the high side, and the stated range covers the measured number.
By their numbers in this assay, from the lowest: compounds 2, 1 and 3 (each within the scatter of the next).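

In this assay the step from octyl to ethyl on the shared core, with hydrogen in place of hexyl, is a 1.1-fold higher number from compound 1 to compound 3 (0.05 log units; within the scatter) and so lies within the scatter. At this position, then, the hexyl portion of the chain makes no difference that this cell assay can detect, and a long chain and a short one cannot be told apart here. No measured property of these compounds is available to explain this result.

Only these two chain lengths can be compared on this core, so a longer chain such as dodecyl, or a chain ending in an amine or a carboxylic acid, could behave differently. Going by these compounds, it also remains open whether a hydroxyl group in place of the whole alkoxy chain would give a similar number.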